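Permeability notes: from compound 2 to compound 3

The source may report more compounds than this note shows. Statements on the series, on what has been measured and on what is new or still open speak of the compounds shown alone.

In an ADME assay on Caco-2 cells (Homo sapiens) for permeability, read by LC-MS, with a stated time of 2 h (on this read-out higher numbers stand for higher permeability and lower numbers for lower permeability), compound 1 (`CCN(Cc1ccc(OCCN2C(=O)CCC2=O)c(C)c1)C(CC(=O)O)c1ccc(Cl)cc1`) gives 3.9 nm/s and compound 2 (`Cc1cc(CN(C)C(CC(=O)O)c2ccc(Cl)cc2)ccc1OCCn1c(=O)ccn(C)c1=O`) gives 0.6 nm/s as the lower of the two numbers, with the gap between them beyond the scatter. Compound 2 therefore stands at the bottom of the short range measured so far. Going by the values given here, no two measured compounds differ in one place only, so the series offers no direct precedent for the next change.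

Compound 3 (`CCN(Cc1ccc(OCCn2c(=O)ccn(C)c2=O)c(C)c1)C(CC(=O)O)c1ccc(Cl)cc1`) differs from compound 2 by a single change (methyl in place of hydrogen on a saturated chain carbon bound to an amine nitrogen): methyl in place of hydrogen on a saturated chain carbon bound to an amine nitrogen. Cut one bond further out, the same difference reads methyl to ethyl.

The expectation starts from compound 2 at 0.6 nm/s as the reference, since nothing measured shows this change on its own. At most a slight rise is expected in this assay and the expected step of a 1.3-fold higher number from compound 2 to compound 3 (0.12 log units; within the scatter) stays within the scatter. Compound 3 is estimated at 0.8 nm/s (expected range 0.35 nm/s to 2 nm/s).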

Compound 3, apparent permeability: 2.1 nm/s
For compound 3 the middle estimate is 2.6-fold (0.42 log units) below the measured one, and the stated range ends below it.
By their numbers in this assay, from the lowest: compound 2; then compounds 3 and 1 (each within the scatter of the next).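

In this assay the series now has its first pair that differs in one place only, and methyl in place of hydrogen on a saturated chain carbon bound to an amine nitrogen gives a 3.5-fold higher number from compound 2 to compound 3 (0.54 log units; beyond the scatter) on the shared core, so the methyl to ethyl difference at this place is large enough to read. With ethyl on both compounds, the other single-place pair gives a 1.9-fold lower number from compound 1 to compound 3 (0.27 log units; within the scatter) for the group of 9 heavy atoms with its six-membered aromatic ring in place of the group of 7 heavy atoms with its five-membered non-aromatic ring, and that step cannot be told from repeat scatter. Going by these compounds alone, of the two steps now available, only the one that enters a single heavy atom lies beyond the scatter, and this rests on one pair for each change.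

Going by these compounds, whether the trend continues with a longer chain such as propyl, or stops with a branched isopropyl or a cyclopropyl, on the amine nitrogen stays open, as does whether the methyl to ethyl step holds with the five-membered ring in place. Nothing at hand accounts for the size of the step.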